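A Methyl in Place of Chloro on the Aromatic Ring

The compounds below may be only part of what the source reports. "The series", "measured", "known", "first", "only" and "open" are said of these compounds alone.

Measured so far in a toxicity assay on the whole organism (strain Icem-CET (SPF Caw)) for cytotoxicity, with Mus musculus as the target; on this read-out lower numbers stand for an effect already at smaller amounts and higher numbers for an effect only at larger amounts of compound:

Compound 1, `C=CCNC(=O)/C(C)=C(\C)c1cc(OC)c(OC)c(OC)c1`: 110 mg/kg
Compound 2, `C/C(C(=O)NC1CC1)=C(/C)c1ccccc1`: 100 mg/kg
Compound 3, `C=CCNC(=O)/C(C)=C(/C)c1ccc(Cl)cc1`: 180 mg/kg

Compound 3 shows the largest of the three numbers, yet its gaps to compound 1 and to compound 2 both lie within the usual scatter of this assay, so the three compounds cannot be told apart on these readings.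

Compound 4, `C=CCNC(=O)/C(C)=C(/C)c1ccc(C)cc1`, has not yet been measured. Its structure differs from compound 3 in one place: methyl in place of chloro on an aromatic carbon. Among the compounds with values here, the change keeps everything else, and no measured pair shows what such a swap does here. With nothing in the three readings pointing one way, no step beyond the scatter is expected in this assay, so the expected step is a 1.2-fold lower number from compound 3 to compound 4 (0.08 log units; within the scatter). Compound 4 is therefore estimated at 150 mg/kg, with a range from 75 mg/kg to 300 mg/kg.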

Compound 4, dose for half-maximal effect: 280 mg/kg
For compound 4 the middle estimate is 1.9-fold (0.27 log units) below the measured one, and the stated range covers the measured number.
By their numbers in this assay, from the lowest: compounds 2, 1, 3 and 4 (each within the scatter of the next, the first and the last beyond it).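

Within the data shown here, the swap of chloro for methyl on this aromatic carbon, para to a large group, gives a 1.6-fold higher number from compound 3 to compound 4 (0.19 log units; within the scatter) in this assay and is the first direct one-place comparison. On this read-out, the two groups cannot be told apart at this position. No measurement shown here offers an explanation for this result.

As far as these compounds go, whether an amine or a carboxylic acid on this aromatic carbon would move the number beyond the scatter remains open. So does whether any other position on the shared core responds more strongly to a single change.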